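Methyl on the indole nitrogen: an untested change

A few compounds are considered here, and "the series" means these few. Any claim that something is new, unique, unknown or untested is made for them only; others in the source may bear on it.

Compound 1, `Oc1ccc(-c2nc(-c3c[nH]c4ccccc34)co2)cc1`, gives 449000 nM in a functional assay on LNCaP cells (Homo sapiens) for cytotoxicity, read by MTT assay, with a stated time of 48 h; a higher number here means a weaker inhibitor, a lower number a stronger inhibitor.
Compound 2, `Clc1ccc(-c2nc(-c3c[nH]c4ccccc34)co2)cc1`, gives 505000 nM in this assay.
Compound 3, `c1ccc2c(-c3cocn3)c[nH]c2c1`, gives 382000 nM in this assay.

Compound 2 sits at one end of these three numbers, but its steps to the others, a 1.1-fold higher number from compound 1 to compound 2 (0.05 log units; within the scatter) and a 1.3-fold lower number from compound 2 to compound 3 (0.12 log units; within the scatter), both lie within the scatter, so the three compounds cannot be told apart on these data. Compound 4, `Cn1cc(-c2coc(-c3ccc(Cl)cc3)n2)c2ccccc21`, differs from compound 2 by methyl in place of hydrogen on an aromatic nitrogen; the methyl enters on an aromatic nitrogen of a five-membered aromatic ring with one nitrogen, part of a fused system of two rings, two ring bonds from the ring atom that bears a large group. Within the data shown here, no measured step touches this nitrogen. The known steps, a 1.1-fold higher number from compound 1 to compound 2 (0.05 log units; within the scatter), a 1.2-fold lower number from compound 1 to compound 3 (0.07 log units; within the scatter) and a 1.3-fold lower number from compound 2 to compound 3 (0.12 log units; within the scatter), all change the other end of the shared core and all stay within the scatter, which gives no guide to this new change. In this assay an expected step of a 1.0-fold lower number from compound 2 to compound 4 (0.00 log units; within the scatter) is therefore estimated here, none beyond the scatter. Compound 4 is estimated at 500000 nM, with a range from 200000 nM to 1250000 nM.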

Compound 4, half-maximal inhibitory concentration: 378000 nM
Estimate against measurement, compound 4: 1.3-fold (0.12 log units) above; low and high end bracket the measured number.
By their numbers in this assay, from the lowest: compounds 4, 3, 1 and 2 (each within the scatter of the next).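

Among these compounds, the first measured change at this aromatic nitrogen gives, in this assay, a 1.3-fold lower number from compound 2 to compound 4 (0.13 log units; within the scatter), so the two compounds cannot be told apart. The nitrogen therefore behaves like the other end of the shared core so far: no change shown at either place moves the number beyond the scatter, and hydrogen and methyl on this nitrogen give numbers that this measurement does not separate. No other measurement shown here bears on this result.

Still open, going by these compounds, is whether a larger group on this nitrogen, such as an ethyl group or a longer chain ending in an amine or a carboxylic acid, would give a number beyond the scatter. Also open, on these data alone, is whether methyl at this nitrogen would stay within the scatter when the far end of the core carries hydroxy, as in compound 1.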